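Replacing the amino-ended side group of compound 3

A few compounds are considered here, and "the series" means these few. Any claim that something is new, unique, unknown or untested is made for them only; others in the source may bear on it.

In an ADME assay on L02 cells (Homo sapiens) for cytotoxicity, read by MTT assay, with a stated time of 48 h (a higher number here means a weaker inhibitor, a lower number a stronger inhibitor), compound 3 (`CCn1c(C(=O)NCCN)ccc1C(CC)(CC)c1ccc(OCC(O)C(C)(C)C)c(C)c1`) gives 2400 nM, and compound 1 (`CCn1c(C(=O)NCCN(C)C)ccc1C(CC)(CC)c1ccc(OCC(O)C(C)(C)C)c(C)c1`) gives 2600 nM. Between these two the data show a 1.1-fold lower number from compound 1 to compound 3 (0.03 log units; within the scatter). Compound 2 (`CCn1c(C(=O)NCC(OC)OC)ccc1C(CC)(CC)c1ccc(OCC(O)C(C)(C)C)c(C)c1`) gives 22200 nM, which leaves a 9.3-fold lower number from compound 2 to compound 3 (0.97 log units; beyond the scatter). Compound 4 (`CCn1c(C(=O)Oc2ccc(CCO)cc2)ccc1C(CC)(CC)c1ccc(OCC(O)C(C)(C)C)c(C)c1`) loses the (2-aminoethyl)amino group on a carbonyl carbon: a group of 10 heavy atoms (8 carbon, 2 oxygen; one six-membered aromatic ring of carbon only) in place of a group of 4 heavy atoms (2 carbon, 2 nitrogen; no ring), on a carbonyl carbon. Among the measured compounds shown here, no measured compound carries the entering group. Like the dimethoxymethyl chain of compound 2, it has no amino group, so the nearest guide is an 8.5-fold higher number from compound 1 to compound 2 (0.93 log units; beyond the scatter). A higher number is therefore expected in this assay, with an estimated step of a 6.3-fold higher number from compound 3 to compound 4 (0.80 log units; beyond the scatter). For compound 4 the expected value is 15000 nM, with an estimated range of 4000 nM to 50000 nM.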

Compound 4, half-maximal inhibitory concentration: 22700 nM
For compound 4 the middle estimate is 1.5-fold (0.18 log units) below the measured one; measured number inside the range.
By their numbers in this assay, from the lowest: compounds 3 and 1 (each within the scatter of the next); then compounds 2 and 4 (each within the scatter of the next).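

The group with one six-membered aromatic ring of carbon only, on a carbonyl carbon, separates compound 4 from the two amino-ended compounds (a 9.5-fold higher number from compound 3 to compound 4 (0.98 log units; beyond the scatter); an 8.7-fold higher number from compound 1 to compound 4 (0.94 log units; beyond the scatter)). Its ring adds nothing measurable to what the ring-free dimethoxymethyl chain already showed (a 1.0-fold higher number from compound 2 to compound 4 (0.01 log units; within the scatter)). In these four compounds, the two with an amino-ended group read apart from the two without one, though nothing shown gives a reason for this. Still open, going by these compounds, is whether an aromatic ring carrying an aminoethyl chain would read with compound 3 or with compound 4, and where a carboxylic acid at the chain end would fall.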